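The source may report more compounds than this note shows. Statements on the series, on what has been measured and on what is new or still open speak of the compounds shown alone.

Compound 1 `Cc1ccc(-n2cc(-c3ccccc3NS(=O)(=O)c3c[nH]c(=O)[nH]c3=O)nn2)cc1` gives 2190 nM in a functional assay on OVCAR-3 cells (Homo sapiens) for antiproliferative activity, read by MTT assay, with a stated time of 24 h; on this read-out higher numbers stand for weaker inhibition and lower numbers for stronger inhibition.
Compound 2 `O=c1[nH]cc(S(=O)(=O)Nc2ccccc2-c2cn(-c3cccc(Cl)c3)nn2)c(=O)[nH]1` gives 2180 nM in this assay.
Compound 3 `Cc1ccccc1-n1cc(-c2ccc(NS(=O)(=O)c3c[nH]c(=O)[nH]c3=O)cc2)nn1` gives 7310 nM in this assay.

Of these three, compound 3 stands highest, beyond the scatter from both others. Compound 4 `O=c1[nH]cc(S(=O)(=O)Nc2ccc(-c3cn(-c4cccc(Cl)c4)nn3)cc2)c(=O)[nH]1` differs from compound 3 in one place: 3-chlorophenyl in place of 2-methylphenyl on an aromatic nitrogen. For the measured compounds named here, the only measured step involving a 3-chlorophenyl entering at that ring nitrogen is a 1.0-fold lower number from compound 1 to compound 2 (0.00 log units; within the scatter), but there the leaving group was 4-methylphenyl rather than 2-methylphenyl, so it bears only partly on this change. With that single step as guide, the expectation is no shift beyond the scatter, which would mean an estimated step of a 1.1-fold lower number from compound 3 to compound 4 (0.05 log units; within the scatter). Compound 4 is therefore expected to give about 6500 nM in this assay, with a range from 2700 nM to 16000 nM.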

Compound 4, half-maximal inhibitory concentration: 2750 nM
Compound 4: middle estimate off by 2.4-fold (0.37 log units), on the high side; low and high end bracket the measured number.
By their numbers in this assay, from the lowest: compounds 2, 1 and 4 (each within the scatter of the next); then compound 3.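

In this assay, the move to 3-chlorophenyl on this aromatic nitrogen gives a 2.7-fold lower number from compound 3 to compound 4 (0.42 log units; beyond the scatter) and so goes beyond the scatter. The same group entering in place of 4-methylphenyl gave a 1.0-fold lower number from compound 1 to compound 2 (0.00 log units; within the scatter) and no shift beyond the scatter, so this swap does not have one fixed outcome across these compounds. No measurement here explains the difference. From the compounds shown here alone, it remains open whether removing the methyl or adding the chlorine drives the step. A plain phenyl, or a phenyl carrying a carboxylic acid, at this nitrogen would help separate the two.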